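Hydrogen for pentyl on selenium: cytotoxicity notes

The compounds below may be only part of what the source reports. "The series", "measured", "known", "first", "only" and "open" are said of these compounds alone.

The series is read in an ADME assay on 184B5 cells (Homo sapiens) for cytotoxicity, read by MTT assay, with a stated time of 72 h; on this read-out higher numbers stand for weaker inhibition of growth and lower numbers for stronger inhibition of growth. Compound 2 `CCCCC[Se]c1nc(NCc2ccc(SC)cc2)c2ccccc2n1` reaches only the limit of this assay, > 100000 nM, so no number is known for it. Compound 1 `COc1ccc(CNc2nc([SeH])nc3ccccc23)cc1` likewise gives a limit and not a number, > 100000 nM. Compound 3 `CCCCC[Se]c1nc([Se]CCCCC)c2ccccc2n1` also returns a limit, > 100000 nM. Compound 2 therefore stands among values that are all limits; the limit of > 100000 nM in this assay, at which 3 of the 3 values shown sit, describes where every measured value sits, and no order among compounds 1, 2 and 3 can be drawn from such data.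

Compound 4 `CSc1ccc(CNc2nc([SeH])nc3ccccc23)cc1` has not yet been measured in this assay. It differs from compound 2 in one place: hydrogen in place of pentyl on a selenium. Compound 1 already carries the same selenium hydrogen, with a different group elsewhere, and sits at the limit. For the measured compounds named here, no step between measured compounds is available, and nothing in the measured set points to a change of growth inhibition on this exchange. The expectation is that the step of a number no higher from compound 2 to compound 4 (the limit leaves the size open) is none beyond the scatter, with compound 4 most likely again reported as a limit. The estimate for compound 4 is 100000 nM, in a range from 30000 nM to 300000 nM.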

Compound 4, concentration for total growth inhibition: 86300 nM
Estimate against measurement, compound 4: 1.2-fold (0.06 log units) above; the range from low to high includes it.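

For the compounds shown here, compound 4 is the only compound of the series with a number and not a limit in this assay, so the exchanges that lead to it can now be read as floors, though not as full steps. Hydrogen in place of pentyl on a selenium gives an at least 1.1-fold lower number from compound 2 to compound 4 (0.06 log units; that floor lies within the scatter), and methylsulfanyl in place of methoxy on an aromatic carbon gives an at least 1.1-fold lower number from compound 1 to compound 4 (0.06 log units; that floor lies within the scatter). Neither exchange is therefore shown to change growth inhibition at this selenium or on this aromatic carbon, and the rest of the set offers no number to compare with compound 4: the limit of > 100000 nM in this assay, at which 3 of the 4 values shown sit.

As far as these compounds go, the true size of both steps stays open, as compound 1 and compound 2 give limits only. Also open, from the compounds shown here alone, is how a propyl chain, a longer chain such as octyl, or an amine on the same selenium would read in this assay, and whether any such group would give a number well clear of the limit.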